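From compound 2 to compound 3: swapping one group

The source may report more compounds than this note shows. Statements on the series, on what has been measured and on what is new or still open speak of the compounds shown alone.

Compound 1 `O=C(O)c1ccc(N(Cc2ccc(C3CCCCC3)cc2)C(=O)[C@H]2CCN2S(=O)(=O)c2c(F)c(F)c(F)c(F)c2F)c(F)c1`: > 10000 nM
Compound 2 `O=C(NO)c1ccc(N(Cc2ccc(C3CCCCC3)cc2)C(=O)[C@H]2CCN2S(=O)(=O)c2c(F)c(F)c(F)c(F)c2F)c(F)c1`: "not determined" (no result reported)

In a functional assay on MDA-MB-231 cells (Homo sapiens) for antiproliferative activity, with a stated time of 72 h (a higher number here means that more compound is needed for the effect, a lower number that less compound is needed), compound 1 gives > 10000 nM, which is a limit and not a number. Compound 2 has no number of its own, and the evidence so far is the limit of > 10000 nM in this assay, at which 1 of the 2 values shown sits. Compound 3 `O=C([C@H]1CCN1S(=O)(=O)c1c(F)c(F)c(F)c(F)c1F)N(Cc1ccc(C2CCCCC2)cc1)c1cc2[nH]ncc2cc1F` comes next. The change is 5-fluoro-1H-indazol-6-yl in place of 2-fluoro-4-(hydroxycarbamoyl)phenyl on an amide-type nitrogen. Among the measured compounds shown here, no measured step sets the size of this change, but a moderate step towards less compound needed than the limit of compound 1 is expected. For compound 3 the expected half-maximal effective concentration is 3000 nM, with an estimated range from 800 nM to 10000 nM.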

Compound 3, half-maximal effective concentration: 2400 nM
The estimate for compound 3 lay 1.3-fold (0.10 log units) above the measured number; the range from low to high includes it.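

On the amide-type nitrogen, 5-fluoro-1H-indazol-6-yl in place of 4-carboxy-2-fluorophenyl gives an at least 4.1-fold lower number from compound 1 to compound 3 (0.61 log units; beyond the scatter) in this assay, so this position tolerates a change that yields a measurable number. From the compounds shown here alone, compound 1 gives > 10000 nM, which is a limit and not a number, so the step's full size stays unknown. Compound 2 has no result of its own, and the only reference for it remains compound 1's limit: the limit of > 10000 nM in this assay, at which 1 of the 3 values shown sits.

The compounds shown leave open whether the fluorine of the indazolyl group matters. They also leave open how 1H-indazol-6-yl without fluorine, or a phenyl carrying an amine, would compare on this nitrogen.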